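The source may hold more compounds than are shown below. What is called first, only, known or untested is meant among the compounds shown, and "the series" means these compounds.

Measured compounds:
compound 1 `Clc1ccc(-c2nn(-c3ccccc3)cc2-c2nc3ccccc3[nH]2)cc1` — in an ADME assay on HaCaT cells (Homo sapiens) for cytotoxicity, read by MTT assay, with a stated time of 48 h (on this read-out lower numbers stand for stronger inhibition and higher numbers for weaker inhibition), compound 1 gives only a limit, > 50000 nM.
compound 2 `Cc1ccc2[nH]c(-c3cn(-c4ccccc4)nc3-c3ccc(Cl)cc3)nc2c1` — in this assay compound 2 gives only a limit, > 50000 nM.
compound 3 `COc1ccc(-c2nn(-c3ccccc3)cc2-c2nc3cc(C)ccc3[nH]2)cc1` — in this assay compound 3 gives only a limit, > 50000 nM.

All three sit at the limit of > 50000 nM in this assay, at which 3 of the 3 values shown sit, so the step that the two limits leave unreadable from compound 1 to compound 2 and the step that the two limits leave unreadable from compound 2 to compound 3 cannot be sized. The change from compound 1 to compound 2 is methyl in place of hydrogen on an aromatic carbon. How the core of compound 1 and the core of compound 3 differ is not broken down here.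

Compound 4 `COc1ccc(-c2nn(-c3ccccc3)cc2-c2nc3cc(C)c(C)cc3[nH]2)cc1` is not yet measured. It differs from compound 3 by methyl in place of hydrogen on an aromatic carbon, the same kind of change as from compound 1 to compound 2, but here the place is also ortho to a methyl group (1 heavy atom). Since compound 1, compound 2 and compound 3 all reached only the limit in this assay, compound 4 is expected to do likewise, an expected step that the limit leaves unreadable from compound 3 to compound 4, and an estimated 60000 nM is given for compound 4.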

Compound 4, half-maximal inhibitory concentration: 21400 nM
Beside the measured number, compound 4's estimate is 2.8-fold (0.45 log units) above it, outside the stated range (below it).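

In this assay, methyl in place of hydrogen on an aromatic carbon, here ortho to a methyl group, gives an at least 2.3-fold lower number from compound 3 to compound 4 (0.36 log units; beyond the scatter). This shows that the change can give a readable step on the core of compound 3, but not that it carries to another core, since the steps among compound 1, compound 2 and compound 3 cannot be read. Those steps stay unreadable because the values are limits and not numbers: the limit of > 50000 nM in this assay, at which 3 of the 4 values shown sit.

On these data alone, whether a second methyl on the core of compound 2 would also give a number in this assay stays open. Also open, as far as these compounds go, is how an amine or a carboxylic acid would read in place of this methyl.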